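This account rests on a few compounds, and the source may have more. Where it says the series, first, only, none or still open, it means among the compounds named here.

Measured in a functional assay on U-87MG ATCC cells for antiproliferative activity against U-87 MG (Homo sapiens), read by MTT assay, with a stated time of 48 h; a lower number here means a stronger inhibitor, a higher number a weaker inhibitor:
- compound 1 `COc1ccc(-c2nc(C)c(C(=O)CSc3nc(N)c(C#N)c(-c4ccccc4)n3)s2)cc1`: 8540 nM
- compound 2 `Cc1nc(-c2ccccc2)sc1C(=O)CSc1nc(N)c(C#N)c(-c2ccccc2)n1`: 29000 nM
- compound 3 `COc1ccc(-c2nc(SCC(=O)c3sc(-c4ccc(Cl)cc4)nc3C)nc(N)c2C#N)cc1`: 10600 nM

Compound 3 at 10600 nM lies within the scatter of compound 1 at 8540 nM. Compound 2 at 29000 nM gives a number higher than both, beyond the scatter.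

The next compound to read is compound 4 `Cc1nc(-c2ccc(Cl)cc2)sc1C(=O)CSc1nc(N)c(C#N)c(-c2ccccc2)n1`, where 4-methoxyphenyl of compound 3 becomes phenyl: hydrogen in place of methoxy on an aromatic carbon. This puts hydrogen in place of methoxy on an aromatic carbon, para to a large group.

Going by the values given here, one measured step bears on this change: a 3.4-fold higher number from compound 1 to compound 2 (0.53 log units; beyond the scatter). It is the same exchange, but on a different six-membered aromatic ring of carbon only, and the rest of that pair also differs from compound 3. Among the compounds with values here, the series holds no measured step at the ring changed here, so the transfer is uncertain. A modest rise in this assay is expected, in the same direction as that single step and perhaps somewhat smaller. The expected change is a 2.6-fold higher number from compound 3 to compound 4 (0.42 log units; beyond the scatter). The estimated value for compound 4 is 28000 nM, with an expected range of 11000 nM to 65000 nM.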

Compound 4, half-maximal inhibitory concentration: 11400 nM
Estimate against measurement, compound 4: 2.5-fold (0.39 log units) above; the range from low to high includes it.
By their numbers in this assay, from the lowest: compounds 1, 3 and 4 (each within the scatter of the next); then compound 2.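

In this assay, the loss of methoxy at this position makes no difference beyond the scatter, a 1.1-fold higher number from compound 3 to compound 4 (0.03 log units; within the scatter), so the larger step seen earlier for the same exchange does not carry over to this ring and core: the same change on two cores in this assay, a 3.4-fold higher number (0.53 log units; beyond the scatter) from compound 1 to compound 2 and a 1.1-fold higher number (0.03 log units; within the scatter) from compound 3 to compound 4, 3.2-fold (0.50 log units) apart, beyond the scatter of two such steps. The new compound also links the two other rings' substituents in one series: chloro in place of hydrogen gives a 2.5-fold lower number from compound 2 to compound 4 (0.41 log units; beyond the scatter), beyond the scatter, whereas chloro in place of methoxy gives a 1.3-fold higher number from compound 1 to compound 4 (0.13 log units; within the scatter), within the scatter. Among compounds 1, 3 and 4, neither the methoxy exchange at this position nor the chloro-for-methoxy exchange separates the numbers; compound 2, with hydrogen on both aromatic rings concerned, is the only one set apart.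

The compounds shown leave open whether methoxy at this position would count for more in a compound with hydrogen rather than chloro on the other aromatic ring, as no such pair appears here. They also leave open whether an amine, a carboxylic acid or a longer alkoxy chain on this aromatic carbon would move the number beyond the scatter of compound 4.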